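The source may report more compounds than this note shows. Statements on the series, on what has been measured and on what is new or still open speak of the compounds shown alone.

Compound 3 `CC[C@H](C)[C@H](N)CN(C(=O)[C@@H]1C[C@H]1c1ccc(F)cc1)c1ccc(-c2ccccc2)cc1` gives the lowest of the two numbers shown in a functional assay for agonist activity at G protein-coupled receptor 88 (Homo sapiens), read by HTRF and cAMP accumulation (on this read-out higher numbers stand for an effect only at larger amounts of compound and lower numbers for an effect already at smaller amounts), namely 600 nM. Its nearest neighbour is compound 1 `CC[C@H](C)[C@H](N)CN(C(=O)[C@@H]1C[C@H]1c1cccc(Cl)c1)c1ccc(-c2ccccc2)cc1`, which in this assay gives 2200 nM, and the step of a 3.7-fold lower number from compound 1 to compound 3 (0.56 log units; beyond the scatter) exchanges one halogenated phenyl for another. Compound 2 `CC[C@H](C)[C@H](N)CN(C(=O)[C@@H]1C[C@H]1c1ccccc1Cl)c1ccc(-c2ccccc2)cc1` reaches only a limit of this assay, at > 25000 nM. Compound 4 `CC[C@H](C)[C@H](N)CN(C(=O)[C@@H]1C[C@H]1c1ccc(C#N)cc1)c1ccc(-c2ccccc2)cc1` differs from compound 3 by cyano in place of fluoro on an aromatic carbon. The steps of an at least 11-fold higher number from compound 1 to compound 2 (1.05 log units; beyond the scatter) and an at least 41-fold lower number from compound 2 to compound 3 (1.61 log units; beyond the scatter) both concern the halogen on that phenyl ring rather than an exchange of one group for another, so they bear only loosely on this change, and no step beyond the scatter is expected. The expected step is a 1.5-fold higher number from compound 3 to compound 4 (0.18 log units; within the scatter). Compound 4 is therefore estimated at 900 nM, with a range from 250 nM to 3500 nM.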

Compound 4, half-maximal effective concentration: > 25000 nM
Compound 4 was reported as a limit; the forecaster's own chance of this, stated with the estimate: 10%; middle value at least 27-fold (1.44 log units) away from the limit.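

Cyano in place of fluoro on this aromatic carbon, para to a large group, proves far from a neutral exchange (an at least 41-fold higher number from compound 3 to compound 4 (1.61 log units; beyond the scatter) and an at least 11-fold higher number from compound 1 to compound 4 (1.05 log units; beyond the scatter)). The change at this carbon alone is enough to take the compound from a measurable value to a limit. In this assay compound 4 gives only a limit, the same one that compound 2 reaches, so the step between those two cannot be read: the limit of > 25000 nM in this assay, at which 2 of the 4 values shown sit.

On these data alone, how a chloro, a methoxy or an amine would behave on this carbon remains open. So does whether any group here gives a lower number than fluoro.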